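Thiazole for Propyl on the Amide of Compound 3

This account rests on a few compounds, and the source may have more. Where it says the series, first, only, none or still open, it means among the compounds named here.

Measured compounds:
compound 1, `CN(C)c1ccc(C(=O)Nc2cccc(NC(=O)COc3ccc4c(c3)NC(=O)CC4)c2)cc1`: in an assay on isolated protein for inhibition of Rho-associated protein kinase 1 (Homo sapiens), read by scintillation counting, radiometric assay and 33P incorporation, with a stated time of 40 min, in the presence of a further agent that is not named here (on this read-out lower numbers stand for stronger inhibition and higher numbers for weaker inhibition), compound 1 gives only a limit, > 10000 nM.
compound 2, `CN(C)c1ccc(C(=O)Nc2cccc(NC(=O)COc3ccc4c(c3)OCCC4=O)c2)cc1`: in this assay compound 2 gives 144 nM.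
compound 3, `CCCC(=O)Nc1cccc(NC(=O)COc2ccc3c(=O)ccoc3c2)c1`: in this assay compound 3 gives 1430 nM.

Among the two numbers, compound 3 has the higher one; compound 2 has the lower. Compound 1 contributes only a limit, (the limit of > 10000 nM in this assay, at which 1 of the 3 values shown sits).

Compound 4 is `Cc1nc(C(=O)Nc2cccc(NC(=O)COc3ccc4c(=O)ccoc4c3)c2)cs1`. It differs from compound 3 by 2-methyl-1,3-thiazol-4-yl in place of propyl on a carbonyl carbon.

Among the compounds with values here, the one measured step, an at least 69-fold lower number from compound 1 to compound 2 (1.84 log units; beyond the scatter), concerns the bicyclic end of the shared core and leaves the amide end untouched, so it does not bear on this change. Within the data shown here, no measured pair shows a swap at the carbonyl carbon. With nothing to anchor it, the writer expects in this assay a step from compound 3 to compound 4 of a 2.9-fold lower number from compound 3 to compound 4 (0.46 log units; beyond the scatter), a moderate lowering, as an estimate only. Compound 4 is therefore expected to give 500 nM, within a range of 100 nM to 2500 nM.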

Compound 4, half-maximal inhibitory concentration: 473 nM
The estimate for compound 4 lay 1.1-fold (0.02 log units) above the measured number, within the range that was stated.
By their numbers in this assay, from the lowest: compound 2; then compound 4; then compound 3. At a limit, above all of these: compound 1.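

In this assay, the only step shown at the amide end of the shared core with the same bicyclic end on both sides is a 3.0-fold lower number from compound 3 to compound 4 (0.48 log units; beyond the scatter) and it is the first evidence on what this position tolerates. It shows that the carbonyl carbon can carry 2-methyl-1,3-thiazol-4-yl, an aromatic ring with more heavy atoms than propyl, and that the number falls beyond the usual scatter. Nothing shown here explains why the number falls.

Open, as far as these compounds go, is whether the ring itself, its nitrogen and sulfur or its methyl accounts for the step, and a thiazole without the methyl would separate these. From the compounds shown here alone, how a piperidine ring, a carboxylic acid or a longer alkyl chain would behave at this carbonyl carbon also remains open.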